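A few compounds are considered here, and "the series" means these few. Any claim that something is new, unique, unknown or untested is made for them only; others in the source may bear on it.

Measured compounds in an in vitro assay on 293-EBNA cells for binding affinity to corticotropin-releasing factor receptor 1 (Homo sapiens); on this read-out higher numbers stand for weaker inhibition and lower numbers for stronger inhibition:
- compound 1, `COCC(COC)N(C)c1nc(C)nc2c1nnn2-c1ccc(C(C)C)cc1Br`: 21.3 nM
- compound 2, `CCC(Nc1nc(C)nc2c1nnn2-c1ccc(C(C)C)cc1Br)C(=O)OC`: 19.4 nM
- compound 3, `CCCC(CN(C)C)Nc1nc(C)nc2c1nnn2-c1ccc(C(C)C)cc1Br`: 38.7 nM

The three numbers sit close together. The steps into compound 3, a 1.8-fold higher number from compound 1 to compound 3 (0.26 log units; within the scatter) and a 2.0-fold higher number from compound 2 to compound 3 (0.30 log units; within the scatter), are both within the scatter, so compound 3 is not separated from compound 1 or compound 2 on this assay, and a 1.1-fold lower number from compound 1 to compound 2 (0.04 log units; within the scatter) is within the scatter as well.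

Compound 4, `CCCCC(CCCC)Nc1nc(C)nc2c1nnn2-c1ccc(C(C)C)cc1Br`, is the next step from compound 3: a group of 9 heavy atoms (9 carbon; no ring) in place of a group of 8 heavy atoms (7 carbon, 1 nitrogen; no ring), on a nitrogen on an aromatic ring. The new 1-butylpentyl group carries no hydrogen-bond acceptor, whereas the group it replaces carried one.

The step that bears most directly on this change is a 2.0-fold higher number from compound 2 to compound 3 (0.30 log units; within the scatter), which exchanged one chain for another on the same nitrogen and stayed within the scatter. The step of a 1.8-fold higher number from compound 1 to compound 3 (0.26 log units; within the scatter), another exchange of a chain on that position, also stayed within the scatter. Three different side groups on the same position have given numbers within the scatter of each other, so no step beyond the scatter is expected for compound 4 in this assay either.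

Compound 4 is therefore estimated at 30 nM, with a range from 12 nM to 80 nM. This estimate means a step of a 1.3-fold lower number from compound 3 to compound 4 (0.11 log units; within the scatter), expected to stay within the scatter.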

Compound 4, inhibition constant: 4.5 nM
Compound 4: middle estimate off by 6.7-fold (0.82 log units), on the high side, and the stated range ends above it.
By their numbers in this assay, from the lowest: compound 4; then compounds 2, 1 and 3 (each within the scatter of the next).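

In this assay, going by these compounds alone, the side group on this nitrogen can move the number beyond the scatter, which no step among the earlier compounds did: 1-butylpentyl gives three such steps (an 8.6-fold lower number from compound 3 to compound 4 (0.93 log units; beyond the scatter); a 4.3-fold lower number from compound 2 to compound 4 (0.63 log units; beyond the scatter); a 4.7-fold lower number from compound 1 to compound 4 (0.68 log units; beyond the scatter)). Compound 4 is the only one of the four whose side group is all carbon, so a hydrogen-bond acceptor in that group is not required for the lowest number in this set. No measurement shown bears on the reason for these steps.

The comparison leaves the absence of an acceptor tied to the size and shape of the chain, since 1-butylpentyl differs from the other side groups in all of these at once. A shorter all-carbon group such as 1-ethylpropyl, or a 1-butylpentyl chain ending in a hydroxyl, would help separate them.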